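Benzoyl ring methyl on the fluoropyridyl series

The source may hold more compounds than are shown below. What is called first, only, known or untested is meant among the compounds shown, and "the series" means these compounds.

Compound 2 `O=C(c1ccccc1)N1CCn2nc(-c3ccc(F)cn3)cc2C1` gives 164 nM in a functional assay on HEK293 cells for negative allosteric modulation of metabotropic glutamate receptor 5 (Homo sapiens), read by calcium flux, with a stated time of 20 min; on this read-out lower numbers stand for stronger inhibition and higher numbers for weaker inhibition. Compound 1 `Cc1ccc(-c2cc3n(n2)CCN(C(=O)c2ccccc2)C3)nc1` gives 244 nM and compound 3 `O=C(c1ccccc1)N1CCn2nc(-c3ccc(Cl)cn3)cc2C1` gives 201 nM; the steps of a 1.5-fold lower number from compound 1 to compound 2 (0.17 log units; within the scatter) and a 1.2-fold higher number from compound 2 to compound 3 (0.09 log units; within the scatter) place compound 2 within the scatter of both neighbours, as a 1.2-fold lower number from compound 1 to compound 3 (0.08 log units; within the scatter) does for the remaining pair. Compound 4 `Cc1cccc(C(=O)N2CCn3nc(-c4ccc(F)cn4)cc3C2)c1` differs from compound 2 by methyl in place of hydrogen on an aromatic carbon. For the measured compounds named here, none of the measured steps touches that ring: all three vary the group on the other aromatic ring, and all stay within the scatter, so no measured step bears directly on this change. Nothing in the series argues for a step beyond the scatter; the expected step is a 1.1-fold higher number from compound 2 to compound 4 (0.04 log units; within the scatter). Compound 4 is expected to give 180 nM, within a range of 60 nM to 540 nM.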

Compound 4, half-maximal inhibitory concentration: 150 nM
The estimate for compound 4 lay 1.2-fold (0.08 log units) above the measured number; the range from low to high includes it.
By their numbers in this assay, from the lowest: compounds 4, 2, 3 and 1 (each within the scatter of the next).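

In this assay, for the compounds shown here, this is the first reading on the benzoyl ring, as the earlier steps all varied the group on the other aromatic ring. Methyl in place of hydrogen, meta to a large group, gives a 1.1-fold lower number from compound 2 to compound 4 (0.04 log units; within the scatter) and so shows that this position accepts a methyl with the number staying within the scatter. No evidence on hand speaks to the reason for this result.

As far as these compounds go, whether a carboxylic acid, an amine or a longer chain at this position would step beyond the scatter stays open. Also open, from the compounds shown here alone, is whether the same methyl behaves alike on the chloro partner, compound 3.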